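Shifting a Methyl Group: Expected Cytotoxicity of Compound 4

A few compounds are considered here, and "the series" means these few. Any claim that something is new, unique, unknown or untested is made for them only; others in the source may bear on it.

Measured in a functional assay on HL-60 cells (Homo sapiens) for cytotoxicity, read by sulforhodamine B assay; on this read-out lower numbers stand for stronger inhibition and higher numbers for weaker inhibition:
- compound 1, `Cc1ccc2c3c(n(C)c(=O)c2c1)-c1ccccc1OCC3`, gives 14100 nM
- compound 2, `COc1ccc(Cn2c3c(c4ccccc4c2=O)CCOc2ccccc2-3)cc1`, gives 4490 nM
- compound 3, `COc1ccc(Cn2c3c(c4cc(C)ccc4c2=O)CCOc2ccccc2-3)cc1`, gives 9260 nM

Compound 2 has the lowest number of the three, so it is the strongest inhibitor here; compound 3 sits above it by a 2.1-fold higher number from compound 2 to compound 3 (0.31 log units; beyond the scatter), and compound 1 sits higher still. Compound 4, `COc1ccc(Cn2c3c(c4ccc(C)cc4c2=O)CCOc2ccccc2-3)cc1`, differs from compound 2 by methyl in place of hydrogen on an aromatic carbon. Among the measured compounds shown here, the only step that bears on this is the one from compound 2 to compound 3, where a methyl entered the same ring at another spot and gave a 2.1-fold higher number from compound 2 to compound 3 (0.31 log units; beyond the scatter). A modest rise of similar size is therefore expected, a 1.4-fold higher number from compound 2 to compound 4 (0.16 log units; within the scatter). Compound 4 is estimated at 6500 nM in this assay, with a range from 3000 nM to 14000 nM.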

Compound 4, half-maximal inhibitory concentration: 4400 nM
Estimate against measurement, compound 4: 1.5-fold (0.17 log units) above; the measured number falls inside the stated range.
By their numbers in this assay, from the lowest: compounds 4 and 2 (each within the scatter of the next); then compounds 3 and 1 (each within the scatter of the next).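

In this assay, a methyl at this place on the ring leaves the number unchanged within the scatter, with a 1.0-fold lower number from compound 2 to compound 4 (0.01 log units; within the scatter), whereas the methyl at the other place in compound 3 gave a 2.1-fold higher number from compound 2 to compound 3 (0.31 log units; beyond the scatter). With this methyl present, 4-methoxyphenyl in place of hydrogen on the saturated chain carbon bound to the aromatic nitrogen gives a 3.2-fold lower number from compound 1 to compound 4 (0.51 log units; beyond the scatter). Nothing available explains either result.

The compounds shown leave open whether this place accepts groups other than methyl, such as a methoxy group, a chlorine atom or an amine.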